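The source may hold more compounds than are shown below. What is called first, only, known or untested is meant among the compounds shown, and "the series" means these compounds.

In a functional assay on PC-3 cells (Homo sapiens) for inhibition, read by sulforhodamine B assay, with a stated time of 48 h (a higher number here means a weaker inhibitor of growth, a lower number a stronger inhibitor of growth), compound 1 `S=C(N/N=C/c1cccs1)Nc1ccc(Cl)cc1` gives > 100000 nM, which is a limit of the assay. Compound 2 `COc1ccc(NC(=S)N/N=C/c2cccs2)cc1` gives > 100000 nM, also a limit, so it has no numerical position in the series. Both compounds therefore sit at one boundary: the limit of > 100000 nM in this assay, at which 2 of the 2 values shown sit. The next compound is compound 3 `CCc1ccc(NC(=S)N/N=C/c2cccs2)cc1`, which differs from compound 2 by ethyl in place of methoxy on an aromatic carbon, with ethyl in place of methoxy on an aromatic carbon, para to a large group. Within the data shown here, the only measured step that bears on this change is a step that the two limits leave unreadable from compound 1 to compound 2, at the same place on the ring, and it offers no size to carry over. No direction can be taken from it, so no change beyond the scatter is expected in this assay. The expected step is an at least 1.1-fold lower number from compound 2 to compound 3 (0.04 log units; that floor lies within the scatter). The estimate for compound 3 is 90000 nM, with an expected range of 30000 nM to 150000 nM.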

Compound 3, concentration for 50% growth inhibition: > 100000 nM
Compound 3: only a limit was reported (the forecaster's own chance of this, stated with the estimate: 65%); at least 1.1-fold (0.04 log units) between middle value and limit.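

In this assay compound 3 gives > 100000 nM, a limit of the assay. Among these compounds, no step among compound 1, compound 2 and compound 3 can be read, as all three rest at one boundary: the limit of > 100000 nM in this assay, at which 3 of the 3 values shown sit. Left open is whether chloro, methoxy and ethyl differ at all in this read-out.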